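Trading a Methoxyphenyl for a Dichlorophenyl

The source may report more compounds than this note shows. Statements on the series, on what has been measured and on what is new or still open speak of the compounds shown alone.

Measured so far:
compound 1 `COc1ccc(CNC(=O)/C(C#N)=C/c2cc(Br)co2)cc1`: > 100000 nM
compound 2 `COc1ccc(CNC(=O)/C(C#N)=C/c2ccc3ccccc3c2)cc1`: 41000 nM

For the measured compounds named here, in a functional assay on SW480 cells (Homo sapiens) for inhibition, read by MTT assay, with a stated time of 72 h (a lower number here means a stronger inhibitor of growth, a higher number a weaker inhibitor of growth), compound 2 gives 41000 nM, the only actual number among the two values. Compound 1 reaches only (the limit of > 100000 nM in this assay, at which 1 of the 2 values shown sits), which is a limit of the assay, not a number. Compound 3 `N#C/C(=C\c1ccc2ccccc2c1)C(=O)NCc1ccc(Cl)c(Cl)c1` keeps the core of compound 2 and differs by 3,4-dichlorophenyl in place of 4-methoxyphenyl on a saturated chain carbon bound to an amide-type nitrogen. Going by the values given here, no step between measured compounds is available to gauge this change. The step from compound 2 to compound 3 is expected to be a 2.1-fold lower number from compound 2 to compound 3 (0.31 log units; beyond the scatter), a modest gain, barely beyond the scatter. Compound 3 is estimated at 20000 nM, within 6000 nM to 70000 nM.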

Compound 3, concentration for 50% growth inhibition: 50000 nM
For compound 3 the middle estimate is 2.5-fold (0.40 log units) below the measured one, within the range that was stated.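

Putting 3,4-dichlorophenyl in place of 4-methoxyphenyl on a saturated chain carbon bound to an amide-type nitrogen gives, in this assay, a 1.2-fold higher number from compound 2 to compound 3 (0.09 log units; within the scatter), so compound 2 and compound 3 cannot be told apart. This first readable step at this position shows that this exchange of one substituted phenyl for another leaves growth inhibition essentially unchanged. Nothing measured here bears on why this is so. Still open, on these data alone, is whether an amine or a carboxylic acid at this position would shift the result. A longer chain carrying the phenyl group remains an open question too.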